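Mirror-Image Pyrrolidine Triol Analogue Against Alpha-Galactosidase

The source may hold more compounds than are shown below. What is called first, only, known or untested is meant among the compounds shown, and "the series" means these compounds.

Measured so far:
compound 1 `Cc1ccc([C@H]2NC[C@@H](O)[C@@H]2O)cc1` — 0%
compound 2 `O[C@H]1[C@H](O)CN[C@@H]1CCCc1ccccc1` — 0%

Working notes. In an assay on isolated protein for inhibition of alpha-galactosidase (Coffea arabica), read by spectrophotometry, tested at 1000 uM (on this read-out lower numbers stand for less inhibition and higher numbers for more inhibition at the one concentration tested (going by the name of the read-out)), compound 1 gives 0%. In this assay compound 2 gives 0%, which is level with compound 1 at the digits shown; the two values lie within the scatter of each other, so no ranking between them is claimed. Among the measured compounds shown here, no pair of measured compounds differs in one place only, so no measured step is available for sizing.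

Compound 3 `O[C@H]1[C@H](CCCc2ccccc2)NC[C@@H]1O` is the next candidate for this assay. It differs from compound 2 as follows: the two compounds have the same atoms and bonds and differ only in configuration as drawn: 3 of 3 stereo elements differ (all stereocentres are inverted: mirror images); a stereocentre at a saturated ring carbon is drawn R in compound 2 and S in compound 3; a stereocentre at a saturated ring carbon is drawn R in compound 2 and S in compound 3; a stereocentre at a saturated ring carbon is drawn R in compound 2 and S in compound 3. The structural change keeps every atom and bond and inverts configuration alone. For the measured compounds named here, with compound 2 showing no measurable inhibition and no measured step to calibrate an inversion of this kind, the expectation is a step of no size beyond the scatter, with any movement more likely upward than downward simply since the starting point is at the floor of the read-out. The step from compound 2 to compound 3 is expected to be a number 5 percentage points higher from compound 2 to compound 3 (within the scatter). Compound 3 is estimated at 5%, in a range from 0% to 30%.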

Compound 3, a percentage reported as inhibition, at one concentration (the size of the read-out at that concentration, not a potency): 0%
Estimate against measurement, compound 3: 5 percentage points above, within the range that was stated.
By their numbers in this assay, from the lowest: compounds 1, 2 and 3 (each within the scatter of the next).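

In this assay, among the compounds shown here, inverting all three stereocentres gives no change at the digits printed from compound 2 to compound 3 (within the scatter), the first measured step and the first read on configuration at these stereocentres. The comparison bears on configuration alone: the fact that compounds 2 and 3 differ only in the configuration as drawn. Compound 2 gives 0% and compound 3 gives 0%, so neither mirror image shows inhibition at the one concentration tested, and no preference for either hand can be read from this pair.

With both values at the bottom of the read-out, the pair cannot show whether configuration would matter in a compound that gives measurable inhibition, so the absence of a step sets no size for this change. Also open, as far as these compounds go, is whether a different group on the shared core, such as a carboxylic acid or an amine at the end of the chain, or a longer chain, would lift either mirror-image form off the bottom of this assay and give an inversion step that can be sized.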